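The source may report more compounds than this note shows. Statements on the series, on what has been measured and on what is new or still open speak of the compounds shown alone.

Measured so far in a functional assay on MCF7 cells (Homo sapiens) for cytotoxicity, read by MTT assay, with a stated time of 48 h (a higher number here means a weaker inhibitor, a lower number a stronger inhibitor), as the read-out:
- compound 1 `CCN(CC)C(=S)SC(CC(C)=O)c1ccccc1` at 23000 nM
- compound 2 `CCN(CC)C(=S)SC(CC(=O)c1ccc(OC)cc1)c1ccccc1` at 4500 nM

Compound 2 holds the lower of the two numbers at 4500 nM in this assay and is the reference for the next comparison. Within the data shown here, the next analogue is compound 3 `CCN(CC)C(=S)SC(CC(=O)c1ccc(Br)cc1)c1ccccc1` with the difference bromo in place of methoxy on an aromatic carbon as its only change: bromo in place of methoxy on an aromatic carbon, or 4-methoxyphenyl to 4-bromophenyl when cut one bond further out.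

Among the measured compounds shown here, only one measured step bears on this, and only loosely: a 5.1-fold lower number from compound 1 to compound 2 (0.71 log units; beyond the scatter) came with 4-methoxyphenyl in place of methyl on a carbonyl carbon. That step exchanged the whole group on the carbonyl carbon, whereas compound 3 keeps the aromatic ring and alters only its substituent. For the measured compounds named here, no measured compound varies that substituent, so the data give no firm direction. A small move is therefore expected, with a 1.1-fold lower number from compound 2 to compound 3 (0.05 log units; within the scatter) as the estimated step and nothing beyond the scatter anticipated. For compound 3 the estimated value is 4000 nM with an expected range from 1500 nM to 11000 nM around it.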

Compound 3, half-maximal inhibitory concentration: 5000 nM
Compound 3: middle estimate off by 1.3-fold (0.10 log units), on the low side; the range from low to high includes it.
By their numbers in this assay, from the lowest: compounds 2 and 3 (each within the scatter of the next); then compound 1.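

In this assay the move from methoxy to bromo on an aromatic carbon para to a large group gives no readable change (a step of a 1.1-fold higher number from compound 2 to compound 3 (0.05 log units; within the scatter)), so at this position these two substituents cannot be told apart, even though they differ in atoms and in hydrogen-bond acceptor count. The lower number relative to methyl on the carbonyl carbon also holds with the second aromatic group (a step of a 4.6-fold lower number from compound 1 to compound 3 (0.66 log units; beyond the scatter)), which shows that the earlier drop is not tied to methoxy and is shared by 4-methoxyphenyl and 4-bromophenyl. Nothing available explains either step.

The compounds shown leave open whether an amine or a carboxylic acid on this same ring carbon would stay level with compound 2 and compound 3 or depart from them, since two substituents give only a narrow view of the position. Also open, going by these compounds, is whether the aromatic ring itself is needed on the carbonyl carbon, or whether a longer chain in place of methyl would give a similarly lower number.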